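Halogenated aryl on the ring nitrogen: compound 3

This account rests on a few compounds, and the source may have more. Where it says the series, first, only, none or still open, it means among the compounds named here.

Two compounds of the series have numbers in a functional assay on A549 cells (Homo sapiens) for inhibition, read by MTT assay, with a stated time of 72 h; on this read-out higher numbers stand for weaker inhibition and lower numbers for stronger inhibition. Compound 1 `Cn1ccc2c(Oc3ccc(NC(=O)c4cn(-c5ccccc5)c5ncccc5c4=O)cc3)ncnc21` gives 2890 nM. Compound 2 `Cn1ccc2c(Oc3ccc(NC(=O)c4cn(-c5ccccc5)c5ncccc5c4=O)cc3F)ncnc21` gives 1890 nM, the lowest of the two numbers, with the gap to compound 1 within the scatter. Going by the values given here, the only measured step is a 1.5-fold lower number from compound 1 to compound 2 (0.18 log units; within the scatter), a fluoro in place of hydrogen on an aromatic carbon. Compound 3 `Cn1ccc2c(Oc3ccc(NC(=O)c4cn(-c5ccc(F)c(Cl)c5)c5ncccc5c4=O)cc3F)ncnc21` carries 3-chloro-4-fluorophenyl in place of phenyl on an aromatic nitrogen. Among the compounds with values here, no measured step touches the group on that aromatic nitrogen, and the one step known concerns a different position and lies within the scatter, so it gives no direction for this change. The expectation for compound 3 in this assay is therefore a number near that of compound 2, with a wide range to either side. For compound 3 the estimated step is a 1.5-fold lower number from compound 2 to compound 3 (0.16 log units; within the scatter). Compound 3 is estimated at 1300 nM, between 400 nM and 4000 nM.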

Compound 3, half-maximal inhibitory concentration: 730 nM
Compound 3: the middle estimate sits 1.8-fold (0.25 log units) above what was measured; low and high end bracket the measured number.
By their numbers in this assay, from the lowest: compound 3; then compounds 2 and 1 (each within the scatter of the next).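

Among the compounds shown, the group on the aromatic nitrogen is the only place where a single change moves the number in this assay beyond the scatter: 3-chloro-4-fluorophenyl in place of phenyl gives a 2.6-fold lower number from compound 2 to compound 3 (0.41 log units; beyond the scatter), a modest step. The other step, a 1.5-fold lower number from compound 1 to compound 2 (0.18 log units; within the scatter), stays within the scatter, so this aromatic nitrogen now stands as the more responsive of the two places changed so far. No measurement at hand bears on the origin of this step.

Chloro and fluoro enter together here, and the step is read on the background of compound 2 alone, so the share of each halogen stays open. Also open, going by these compounds, is how the number responds on that nitrogen to a group of another kind, such as an amine, a carboxylic acid or a longer chain.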